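The compounds below may be only part of what the source reports. "The series", "measured", "known", "first", "only" and "open" are said of these compounds alone.

Values in a functional assay on HeLa cells (Homo sapiens) for inhibition, read by CCK-8 assay, with a stated time of 72 h, tested at 8 uM (a lower number here means less inhibition of growth, a higher number more inhibition of growth at the concentration tested), for the compounds measured so far

- compound 1 `COc1ccc(SCc2ccc(C(=O)Nc3ccccc3N)cc2)cc1` gives 79.7%
- compound 2 `CCc1ccc(SCc2ccc(C(=O)Nc3ccccc3N)cc2)cc1` gives 71%
- compound 3 `Nc1ccccc1NC(=O)c1ccc(CSc2ccc(Br)cc2)cc1` gives 38.2%

Compound 3 holds the lowest of these three numbers. Two steps lead down to it, a number 41.5 percentage points lower from compound 1 to compound 3 (beyond the scatter) and a number 32.8 percentage points lower from compound 2 to compound 3 (beyond the scatter), and in each of them bromo replaces another group on an aromatic carbon. The remaining step, a number 8.7 percentage points lower from compound 1 to compound 2 (within the scatter), shows no real separation between the other two compounds.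

The next compound, compound 4 `Nc1ccccc1NC(=O)c1ccc(CSCCc2ccccc2)cc1`, keeps the shared core and changes only what sits on the sulfur: phenethyl in place of 4-bromophenyl on a sulfur. In words, this is phenethyl in place of 4-bromophenyl on a sulfur.

For the measured compounds named here, no measured step makes this kind of change, so the evidence is indirect. Compound 4 loses the bromine, and the two measured compounds without it stand clearly higher than compound 3 . However, neither of those two carries phenethyl on the sulfur, so only part of those large steps can reasonably be carried over. A rise is therefore expected, though a less certain and smaller one. The expected move is a number 16.8 percentage points higher from compound 3 to compound 4 (beyond the scatter) in this estimate. For compound 4 the estimated value is 55%, with an expected range from 28% to 82%.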

Compound 4, percent growth inhibition at one concentration: 74.8%
The estimate for compound 4 lay 19.8 percentage points below the measured number; low and high end bracket the measured number.
By their numbers in this assay, from the lowest: compound 3; then compounds 2, 4 and 1 (each within the scatter of the next).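

In this assay, phenethyl in place of 4-bromophenyl on a sulfur gives a number 36.6 percentage points higher from compound 3 to compound 4 (beyond the scatter) and so lifts the number well clear of the low value of compound 3. Phenethyl is the first group at this place that is not a substituted phenyl, yet it stands level with both substituted phenyl groups that gave high numbers, with a number 3.8 percentage points higher from compound 2 to compound 4 (within the scatter) and a number 4.9 percentage points lower from compound 1 to compound 4 (within the scatter) as the two comparisons. High inhibition at this single concentration therefore does not depend on a phenyl ring bonded straight to the sulfur, and among the four compounds only compound 3 falls out of the group. Nothing measured here explains the low number with 4-bromophenyl or the high number with phenethyl.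

Going by these compounds, it remains open whether a bromo on the ring of phenethyl would pull the number down as it does in compound 3, or whether the low value belongs to 4-bromophenyl alone. Also open, on these data alone, is how a benzyl group, a longer chain ending in phenyl, or a chain ending in an amine or a carboxylic acid would fare on the sulfur.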